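The source may hold more compounds than are shown below. What is called first, only, known or untested is meant among the compounds shown, and "the series" means these compounds.

Three compounds have been measured so far:

compound 1, `O=C(CO[N+](=O)[O-])Nc1ccc(C(=O)/C=C/c2ccco2)cc1`, giving 40%
compound 2, `COc1ccc(/C=C/C(=O)c2ccc(NC(=O)C(C)Br)cc2)cc1`, giving 38%
compound 3, `O=C(COCc1c(-c2ccccc2)no[n+]1[O-])Nc1ccc(C(=O)/C=C/c2ccc(Cl)cc2)cc1`, giving 75%

All three were tested in a functional assay on the whole organism (strain albino) for inhibition, with Rattus norvegicus as the target, read by paw edema, with stated times of 30 min and 4 h, at a dose of 100 mg/kg by the oral route; on this read-out higher numbers stand for more inhibition at the one dose given (going by the name of the read-out) and lower numbers for less inhibition. Among these three numbers compound 3 stands highest. The nearest to it is compound 1, and the gap between them lies beyond the usual scatter of such measurements; the furthest is compound 2, whose gap also lies beyond the scatter. So compound 3 is separated from both of the others by more than measurement noise.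

Compound 4, `O=C(COCc1c(-c2ccccc2)no[n+]1[O-])Nc1ccc(C(=O)/C=C/c2ccco2)cc1`, has not yet been measured in this assay. It shares its core and its side chain with compound 3 and differs in one place only: furan-2-yl in place of 4-chlorophenyl on a double-bonded chain carbon bound to a double-bonded chain carbon. Among the compounds with values here, no pair of measured compounds differs by just this change, so the size of the step has to be judged from the whole set. Compound 1 also carries a furan-2-yl group at this position and gives 40% in this assay, but it carries a different amide side chain, so it is not a clean comparison. Tentatively, a moderate fall is expected, with the step from compound 3 to compound 4 estimated at a number 15 percentage points lower from compound 3 to compound 4 (beyond the scatter). Compound 4 is therefore expected to give about 60%, with a likely range from 42% to 76%.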

Compound 4, a percentage reported as inhibition, in the whole organism at one dose (the size of the read-out at that dose, not a potency): 58%
Estimate against measurement, compound 4: 2 percentage points above; measured number inside the range.
By their numbers in this assay, from the lowest: compounds 2 and 1 (each within the scatter of the next); then compound 4; then compound 3.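

With core and side chain held constant, putting furan-2-yl in place of 4-chlorophenyl gives a number 17 percentage points lower from compound 3 to compound 4 (beyond the scatter) in this assay. Within the data shown here, this shows that the group at this place affects the read-out, which the earlier compounds could not show, as they differ from one another in more than one place. The change does not remove the effect, however: compound 4 still gives 58%, while compound 1, which carries the same furan-2-yl group with a different amide side chain, gives 40%, so furan-2-yl here does not fix the number by itself. Nothing available explains why the number falls with this change.

The change alters the ring and removes the chlorine at once, so a plain phenyl group and a thiophen-2-yl group at this place would be needed to begin separating those two differences. Each number also comes from a single dose, so the step gives the size of the inhibition at that dose and says nothing about potency.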